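Adding a chloro group to compound 1

The compounds below may be only part of what the source reports. "The series", "measured", "known", "first", "only" and "open" are said of these compounds alone.

For the measured compounds named here, in a functional assay on K562 cells (Homo sapiens) for inhibition, read by trypan blue exclusion, with a stated time of 24 h, tested at 10 uM (on this read-out higher numbers stand for more inhibition of growth at the one concentration tested and lower numbers for less inhibition of growth), compound 1 `Cc1ccccc1OCC(=O)Nc1ccccc1C(N)=O` gives 19.7%, the only true number so far. Compound 2 `Cc1ccc(OCC(=O)Nc2ccccc2C(N)=O)cc1` reads < 10%, which is a limit of this assay and not a number. Compound 3 `NC(=O)c1ccccc1NC(=O)COc1ccc(Cl)cc1Cl` reads < 10%, likewise a limit. Compound 4 `Cc1ccccc1OCC(=O)Nc1ccc(Cl)cc1C(N)=O` is compound 1 with one change: chloro in place of hydrogen on an aromatic carbon, a chloro in place of hydrogen on an aromatic carbon. Going by the values given here, the only measured step, a number at least 9.7 percentage points lower from compound 1 to compound 2 (that floor lies within the scatter), swaps 2-methylphenyl for 4-methylphenyl, so it is a different change and gives no size to carry over. No step beyond the scatter is therefore expected, in either direction. The expected step is a number 1.7 percentage points lower from compound 1 to compound 4 (within the scatter). For compound 4 the estimate is 18%, with an expected range from 8% to 32%.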

Compound 4, percent growth inhibition at one concentration: 75.9%
The estimate for compound 4 lay 57.9 percentage points below the measured number; the whole stated range lies below it.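

Chloro in place of hydrogen on the aromatic carbon meta to the carbamoyl group and para to a large group gives a number 56.2 percentage points higher from compound 1 to compound 4 (beyond the scatter) in this assay. For the compounds shown here, the only earlier step moved a methyl group on the other aromatic ring, and its floor lay within the scatter. This step shows that one added chlorine atom at this position can shift growth inhibition far beyond that scatter.

Going by these compounds, whether a fluoro group, a methoxy group or an amine on this same carbon would give a similar step remains open. Whether chloro here would do the same with the 4-methylphenyl group of compound 2 also remains open, and the assay floor would limit that comparison: the limit of < 10% in this assay, at which 2 of the 4 values shown sit.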